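Triazene series: methyl added to the ring of compound 2

The source may report more compounds than this note shows. Statements on the series, on what has been measured and on what is new or still open speak of the compounds shown alone.

Compound 1 `CN(C)CCCNc1ccc(/N=N/c2ccc([N+](=O)[O-])cc2)cc1` was tested in an ADME assay on BHK-21 cells (Mesocricetus auratus) for cytotoxicity, read by MTT assay, with a stated time of 96 h; a higher number here means that more compound is tolerated, a lower number that less compound is tolerated. In this assay compound 1 gives only a limit, > 100000 nM. Compound 3 `CN(C)CCCN(/N=N/c1cc(F)ccc1F)c1cccc(C(F)(F)F)c1` gives 54000 nM in this assay. Compound 2 `CN(/N=N/c1ccccc1)c1ccccc1` likewise gives only a limit in this assay, > 100000 nM. Compound 2 therefore stands at the limit of > 100000 nM in this assay, at which 2 of the 3 values shown sit, and no number is known for it. Compound 4 `Cc1ccc(/N=N/N(C)c2ccccc2)cc1` is not yet measured in this assay. It differs from compound 2 in one small place: methyl in place of hydrogen on an aromatic carbon. Among the compounds with values here, no step between measured compounds is available to gauge such a change. The expected step is a step that the limit leaves unreadable from compound 2 to compound 4, none beyond the scatter. In this assay compound 4 is estimated at 150000 nM, between 60000 nM and 400000 nM, most likely again reported only as a limit.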

Compound 4, half-maximal cytotoxic concentration: > 100000 nM
Compound 4 was reported as a limit; the forecaster's own chance of this, stated with the estimate: 70%; the middle value does not contradict the limit.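

In this assay compound 2 and compound 4 both stand only as limits, so no step can be read between them: the limit of > 100000 nM in this assay, at which 3 of the 4 values shown sit.

Whether methyl in place of hydrogen on an aromatic carbon changes the tolerated concentration at all stays open in the compounds shown.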